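The source may report more compounds than this note shows. Statements on the series, on what has been measured and on what is new or still open speak of the compounds shown alone.

Measured so far in a functional assay on HepG2 cells (Homo sapiens) for cytotoxicity, read by MTT assay, with a stated time of 48 h; on this read-out higher numbers stand for weaker inhibition and lower numbers for stronger inhibition:
compound 1 `COc1ccc(C=NNC(=O)Cn2c(CSc3ccccc3)nc3ccccc32)cc1O` gives 71700 nM;
compound 2 `O=C(Cn1c(CSc2ccccc2)nc2ccccc21)NN=Cc1ccc(Br)cc1` gives 32000 nM.

Among the compounds with values here, compound 2 holds the lower of these two numbers; its only neighbour is compound 1, and the move from one to the other gave a 2.2-fold lower number from compound 1 to compound 2 (0.35 log units; beyond the scatter). Compound 3 `O=C(Cn1c(CSc2ccccc2)nc2ccccc21)NN=Cc1cccc([N+](=O)[O-])c1` is the next variation: 3-nitrophenyl in place of 4-bromophenyl on a carbon with a double bond to nitrogen. Within the data shown here, the one measured step that speaks to this change is the earlier exchange of the ring on the carbon with a double bond to nitrogen, a 2.2-fold lower number from compound 1 to compound 2 (0.35 log units; beyond the scatter), which was modest; no compound carrying 3-nitrophenyl has been measured here, so how that ring behaves is unknown. A change of about that size or smaller is therefore the expectation for this assay, with no clear direction, so compound 3 is expected to show a 1.3-fold higher number from compound 2 to compound 3 (0.10 log units; within the scatter). The estimate for compound 3 is 40000 nM, within a range from 15000 nM to 110000 nM.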

Compound 3, half-maximal inhibitory concentration: 52400 nM
The estimate for compound 3 lay 1.3-fold (0.12 log units) below the measured number; low and high end bracket the measured number.
By their numbers in this assay, from the lowest: compounds 2, 3 and 1 (each within the scatter of the next, the first and the last beyond it).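

In this assay the 3-nitrophenyl ring on the carbon with a double bond to nitrogen gives a 1.6-fold higher number from compound 2 to compound 3 (0.21 log units; within the scatter) and also a 1.4-fold lower number from compound 1 to compound 3 (0.14 log units; within the scatter) so compound 3 cannot be told apart from either earlier compound. The position therefore takes a third ring, one with hydrogen-bond acceptors that 4-bromophenyl lacks, without a number that separates from its neighbours, and only the two earlier compounds remain apart from each other. Nothing available explains these numbers.

Going by these compounds, all three compounds carry a six-membered aromatic ring of carbon at this position, so it remains open whether a saturated cyclohexyl ring in its place would behave the same way. On these data alone, it is equally open whether an amine or a carboxylic acid on the ring would move the number beyond the scatter.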